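The compounds below may be only part of what the source reports. "The series", "measured", "known", "first", "only" and "open" are said of these compounds alone.

In a functional assay on DLD-1 cells (Homo sapiens) for cytotoxicity, with a stated time of 48 h (a higher number here means a weaker inhibitor, a lower number a stronger inhibitor), three compounds on a shared core have been measured. Compound 1 (`Cc1ccc2oc(/C=C/[S+](C)[O-])cc(=O)c2c1`) gives 7000 nM. Compound 2 (`C[S+]([O-])/C=C/c1cc(=O)c2cc(C#N)ccc2o1`) gives > 10000 nM, which is a limit of the assay and not a number. Compound 3 (`COc1ccc2oc(/C=C/[S+](C)[O-])cc(=O)c2c1`) gives 5700 nM. That places compound 3 level with compound 1, as the measured step is a 1.2-fold lower number from compound 1 to compound 3 (0.09 log units; within the scatter).

Compound 4 (`C[S+]([O-])/C=C/c1cc(=O)c2cc(Br)ccc2o1`) carries bromo in place of methoxy on an aromatic carbon. Among the compounds with values here, no bromo compound has been measured, so the nearest guide is the other exchanges at this aromatic carbon. Besides the methoxy and methyl exchange above, these are an at least 1.4-fold higher number from compound 1 to compound 2 (0.15 log units; that floor lies within the scatter) and an at least 1.7-fold lower number from compound 2 to compound 3 (0.24 log units; that floor lies within the scatter). None of these steps is shown to exceed the scatter, so no step beyond the scatter is expected in this assay, although a drift towards a higher number would not surprise. The expected change is a 1.2-fold higher number from compound 3 to compound 4 (0.09 log units; within the scatter). For compound 4 the estimated value is 7000 nM, with an expected range from 3000 nM to 15000 nM.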

Compound 4, half-maximal inhibitory concentration: 4500 nM
For compound 4 the middle estimate is 1.6-fold (0.19 log units) above the measured one; the range from low to high includes it.
By their numbers in this assay, from the lowest: compounds 4, 3 and 1 (each within the scatter of the next). At a limit, above all of these: compound 2.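

In this assay, within the data shown here, bromo is the first group at this aromatic carbon whose step is printed as beyond the scatter (an at least 2.2-fold lower number from compound 2 to compound 4 (0.34 log units; beyond the scatter)). Compound 2 stands at a limit of the assay and not at a number, so that step gives only a floor: the limit of > 10000 nM in this assay, at which 1 of the 4 values shown sits. The other two steps stay within the scatter (a 1.3-fold lower number from compound 3 to compound 4 (0.10 log units; within the scatter); a 1.6-fold lower number from compound 1 to compound 4 (0.19 log units; within the scatter)), so bromo, methoxy and methyl cannot be told apart at this place.

Going by these compounds, what an amine or a carboxylic acid on this aromatic carbon would give remains open. Also open, on these data alone, is whether any exchange here can move the number beyond the scatter from the level shared by compounds 1, 3 and 4.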